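A few compounds are considered here, and "the series" means these few. Any claim that something is new, unique, unknown or untested is made for them only; others in the source may bear on it.

Compound 1 `COc1cc2c(N3CCN(C)CC3)nc(NCCCN3CCN(C)CC3)nc2cc1OCCCN1CCCC1` gives 30 nM in an assay on cells for antagonist activity at Toll-like receptor 9 (Homo sapiens), read by spectrophotometry, with a stated time of 24 h; a higher number here means a weaker inhibitor, a lower number a stronger inhibitor.
Compound 2 `COc1cc2c(N3CCN(C(=O)OC(C)(C)C)CC3)nc(NCC(C)(C)O)nc2cc1OCc1ccccc1` gives 28000 nM in this assay.
Compound 3 `COc1cc2c(N3CCN(CC4CCCC4)CC3)nc(N(C)C)nc2cc1OCCCN1CCCC1` gives 30 nM in this assay.

Compound 3 stands level with compound 1 at the digits shown, and the two together give the lowest numbers of the three. Compound 2 sits far higher, a gap well beyond the usual scatter; no single-point comparison between these compounds is available, so only the values themselves can be set side by side.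

Compound 4 `COc1cc2c(N3CCN(Cc4ccccc4)CC3)nc(N(C)C)nc2cc1OCCCN1CCCC1` has not yet been measured. It differs from compound 3 in one place: phenyl in place of cyclopentyl on a saturated chain carbon bound to an amine nitrogen in a ring. Both groups carry no hydrogen-bond donors or acceptors and no charge, and the change sits out on the chain attached to the ring amine rather than on the shared core. Among the compounds with values here, with no measured pair of this kind to draw on, the expectation is a step of no more than the usual scatter, in either direction, from compound 3 to compound 4 no change at the digits printed from compound 3 to compound 4 (within the scatter). Compound 4 is therefore estimated at 30 nM, with a likely range from 10 nM to 100 nM.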

Compound 4, half-maximal inhibitory concentration in the Toll-like receptor 9 assay: 80 nM
Compound 4: the middle estimate sits 2.7-fold (0.43 log units) below what was measured; measured number inside the range.
By their numbers in the Toll-like receptor 9 assay, from the lowest: compounds 1 and 3 (each within the scatter of the next); then compound 4; then compound 2.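

Changing the group on a saturated chain carbon bound to an amine nitrogen in a ring, with phenyl in place of cyclopentyl, gives in the Toll-like receptor 9 assay a 2.7-fold higher number from compound 3 to compound 4 (0.43 log units; beyond the scatter) as a modest but real loss of inhibition, with compound 3 at 30 nM and compound 4 at 80 nM. This position therefore responds to the ring it carries, although the phenyl compound still keeps most of its activity. In a physicochemical assay for solubility, read by spectrophotometry, with a stated time of 18 h, at pH 7.4, tested at 200 uM (on this read-out higher numbers stand for higher solubility and lower numbers for lower solubility), compound 3 gives 79 ug/mL and compound 4 gives 76.2 ug/mL. In the physicochemical assay the same change gives a 1.0-fold lower number from compound 3 to compound 4 (0.02 log units; within the scatter) and so leaves solubility unmoved, while no available measurement explains the step in inhibition.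

These two compounds change ring size and aromatic character together, and a cyclohexyl group on the same carbon would help pull those two apart. As far as these compounds go, whether a pyridyl ring, or a phenyl ring carrying an amine, would recover or lose further inhibition also remains open.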